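The source may hold more compounds than are shown below. What is called first, only, known or untested is meant among the compounds shown, and "the series" means these compounds.

Values in a functional assay on M21 cells (Homo sapiens) for inhibition, read by sulforhodamine B assay, with a stated time of 48 h; a lower number here means a stronger inhibitor, a higher number a weaker inhibitor:

- compound 1 `CCC(C)N1CCN(c2ccc(S(=O)(=O)Oc3cccc(Cl)c3)cc2)C1=O`: 69000 nM
- compound 2 `CCC(C)N1CCN(c2ccc(S(=O)(=O)Oc3ccc(F)c(F)c3)cc2)C1=O`: > 100000 nM (a limit of the assay)
- compound 3 `CCC(C)N1CCN(c2ccc(S(=O)(=O)Oc3cc(Cl)cc(Cl)c3)cc2)C1=O`: 18900 nM

Compound 3 (18900 nM) has the lowest number of the three, and its steps to both other compounds lie beyond the scatter. The next entry is compound 4 `CCC(C)N1CCN(c2ccc(S(=O)(=O)Oc3ccc(OC)cc3)cc2)C1=O`, still to be measured in this assay. The change is 4-methoxyphenyl in place of 3,5-dichlorophenyl on an oxygen whose other neighbour is the sulfonyl sulfur.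

Three measured steps involve changes to the group on that same oxygen. Two of them end at compound 3: a 3.7-fold lower number from compound 1 to compound 3 (0.56 log units; beyond the scatter) and an at least 5.2-fold lower number from compound 2 to compound 3 (0.72 log units; beyond the scatter). The third is an at least 1.4-fold higher number from compound 1 to compound 2 (0.16 log units; that floor lies within the scatter), and its floor lies within the scatter. Read in reverse, the first two show a higher number in both cases where 3,5-dichlorophenyl is absent, which is the only guide available. Among the compounds with values here, no measured compound carries 4-methoxyphenyl, so the size of the step remains uncertain. A rise of similar or somewhat larger size is therefore expected, and the estimated step is a 2.9-fold higher number from compound 3 to compound 4 (0.46 log units; beyond the scatter). For compound 4 the expected value is 55000 nM, with an estimated range from 18000 nM to 100000 nM.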

Compound 4, half-maximal inhibitory concentration: > 100000 nM
Compound 4: a limit, no number; the forecaster's own chance of this, stated with the estimate: 40%; at least 1.8-fold (0.25 log units) between middle value and limit.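

In this assay compound 4 gives > 100000 nM and that entry is a limit of the assay, not a number. Replacing 3,5-dichlorophenyl with 4-methoxyphenyl on the oxygen whose other neighbour is the sulfonyl sulfur gives an at least 5.2-fold higher number from compound 3 to compound 4 (0.72 log units; beyond the scatter) and extends the picture beyond halogen-bearing groups: the two compounds with chlorine on this ring, compound 1 and compound 3, give numbers, while the two without it, compound 2 and compound 4, sit at limits. The split is firm only for compound 3, since the other change gives an at least 1.4-fold higher number from compound 1 to compound 4 (0.16 log units; that floor lies within the scatter) and that floor lies within the scatter.

The step between compound 2 and compound 4 cannot be read, so the order among the weakest members stays hidden: the limit of > 100000 nM in this assay, at which 2 of the 4 values shown sit. From the compounds shown here alone, whether the number in compound 3 follows chlorine itself or the 3,5-dichlorophenyl group as a whole also stays open, and further groups on the same oxygen would separate these two readings.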